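This account rests on a few compounds, and the source may have more. Where it says the series, first, only, none or still open, it means among the compounds named here.

Measured so far in a functional assay on UO-31 cells (Homo sapiens) for inhibition, read by sulforhodamine B assay, with a stated time of 48 h, tested at 0.1 uM; on this read-out higher numbers stand for a weaker effect at the one concentration tested and lower numbers for a stronger effect:
- compound 1 `O=C(Nc1cccc(-n2cc(-c3ccncc3)c(-c3cc(O)cc(Cl)c3)n2)c1)Nc1ccc(Cl)c(Cl)c1`: 93%
- compound 2 `COc1cc(Cl)cc(-c2nn(-c3cccc(NC(=O)Nc4ccc(Cl)c(C(F)(F)F)c4)c3)cc2-c2ccncc2)c1`: 55%
- compound 3 `COc1cc(Cl)cc(-c2nn(-c3cccc(NC(=O)Nc4ccc(Cl)c(Cl)c4)c3)cc2-c2ccncc2)c1`: 500%

Compound 3 stands highest of the three; the steps to it, a number 407 percentage points higher from compound 1 to compound 3 (beyond the scatter) and a number 445 percentage points higher from compound 2 to compound 3 (beyond the scatter), were both large and beyond the scatter, each from a single small change at an aromatic ring.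

Compound 4 `COc1cc(Cl)cc(-c2nn(-c3cccc(NC(=O)c4cccc(C(F)(F)F)c4)c3)cc2-c2ccncc2)c1` differs from compound 3 at the carbonyl carbon: 3-(trifluoromethyl)phenyl in place of (3,4-dichlorophenyl)amino on a carbonyl carbon. For the measured compounds named here, no measured step touches this place; the step of a number 445 percentage points higher from compound 2 to compound 3 (beyond the scatter) concerns the same distal ring but only its substituent, so it bears on the change loosely at most. Given that small changes elsewhere moved this assay by large amounts, a large step is expected here too, most likely downward, toward the numbers of compound 1 and compound 2. The expected step is a number 380 percentage points lower from compound 3 to compound 4 (beyond the scatter); compound 4 is estimated at 120%, within 40% to 400%.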

Compound 4, a percentage reported as activity, at one concentration (the size of the read-out at that concentration, not a potency): 88%
Compound 4: middle estimate off by 32 percentage points, on the high side, and the stated range covers the measured number.
By their numbers in this assay, from the lowest: compound 2; then compounds 4 and 1 (each within the scatter of the next); then compound 3.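

In this assay, for the compounds shown here, the exchange at the carbonyl carbon gives a number 412 percentage points lower from compound 3 to compound 4 (beyond the scatter), the first measured step at this position, and it is as large as the earlier single changes on the aromatic rings. The same place also gives a number 33 percentage points higher from compound 2 to compound 4 (beyond the scatter), so the direction of the change depends on which (phenyl)amino group leaves. Nothing available explains either direction.

From the compounds shown here alone, both steps change the amino nitrogen and the ring substituents together, so their separate contributions remain open. A benzyl or piperidine group on the carbonyl carbon would extend this comparison.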